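Methyl on the saturated ring of compound 1

The source may report more compounds than this note shows. Statements on the series, on what has been measured and on what is new or still open speak of the compounds shown alone.

Compound 1 `O=C1NCCN(c2cccc(Cl)c2)N1` gives 2100 nM in a functional assay on cells for inhibition of Polyunsaturated fatty acid 5-lipoxygenase (Homo sapiens) (a lower number here means a stronger inhibitor, a higher number a weaker inhibitor), the second highest of the three numbers available. Its nearest companion is compound 2 `CSc1cccc(N2CCNC(=O)N2)c1`, which in this assay gives 2200 nM; the step of a 1.0-fold higher number from compound 1 to compound 2 (0.02 log units; within the scatter) sets methylsulfanyl in place of chloro on an aromatic carbon. Compound 3 `O=C1NCCN(c2cccc(OCc3ccccc3)c2)N1`, carrying benzyloxy on the aromatic ring, gives 200 nM in this assay, the lowest of the three and beyond the scatter from compound 1.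

Compound 4 `CC1CN(c2cccc(Cl)c2)NC(=O)N1` differs from compound 1 by methyl in place of hydrogen on a saturated ring carbon of the six-membered non-aromatic ring with three nitrogen. Within the data shown here, neither the single measured step nor the gap to compound 3 touches that ring; both concern the substituent on the aromatic ring, so no measured change bears on this one. With nothing pointing in either direction, a step no larger than the scatter is expected, no change at the digits printed from compound 1 to compound 4 (within the scatter). Compound 4 is therefore estimated at 2100 nM, within 800 nM to 5500 nM.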

Compound 4, half-maximal inhibitory concentration: 2700 nM
Estimate against measurement, compound 4: 1.3-fold (0.11 log units) below; low and high end bracket the measured number.
By their numbers in this assay, from the lowest: compound 3; then compounds 1, 2 and 4 (each within the scatter of the next).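

The earlier compounds vary only the substituent on the aromatic ring, and this is the only step shown that reaches the saturated ring. In this assay, methyl in place of hydrogen on a saturated ring carbon gives a 1.3-fold higher number from compound 1 to compound 4 (0.11 log units; within the scatter), so this added carbon on the saturated ring leaves the number of the core of compound 1 within the scatter. No further data bear on this result.

A single methyl says nothing about whether a longer chain, an amine or a carboxylic acid on this same ring carbon would also stay within the scatter of compound 1. It also leaves open whether the methyl step would read the same on the benzyloxy-bearing compound 3, which gives 200 nM.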